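This account rests on a few compounds, and the source may have more. Where it says the series, first, only, none or still open, it means among the compounds named here.

For the measured compounds named here, compound 2 `Cc1c(Cl)cccc1C(=O)OC(CCN(C)C)c1ccc(Cl)cc1` is one of two compounds measured in an assay on NIH3T3 cells with Urotensin-2 receptor (Homo sapiens) as the target; on this read-out lower numbers stand for smaller maximal responses and higher numbers for larger maximal responses. Compound 2 gives 118%, and compound 1 `Cc1ccccc1C(=O)OC(CCN(C)C)c1ccc(Cl)cc1` gives 126%; the step of a number 8 percentage points lower from compound 1 to compound 2 (within the scatter) sits within the scatter, so the two cannot be told apart. Compound 3 `Cc1ccc(C)c(C(=O)OC(CCN(C)C)c2ccc(Cl)cc2)c1` differs from compound 2 by 2,5-dimethylphenyl in place of 3-chloro-2-methylphenyl on a carbonyl carbon. Going by the values given here, the only step at hand, a number 8 percentage points lower from compound 1 to compound 2 (within the scatter), exchanged a hydrogen for a chloro and produced nothing beyond the scatter; here the chloro leaves and a methyl enters, so no step beyond the scatter is expected in this assay. Compound 3 is estimated to give 122%, with a range from 105% to 139%. The expected step is a number 4 percentage points higher from compound 2 to compound 3 (within the scatter).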

Compound 3, largest response reached (reported as efficacy), in percent of the reference or control that the assay uses: 86%
Beside the measured number, compound 3's estimate is 36 percentage points above it, outside the stated range (below it).
By their numbers in this assay, from the lowest: compound 3; then compounds 2 and 1 (each within the scatter of the next).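

In this assay the group on the carbonyl carbon proves able to change the maximal response: the swap to 2,5-dimethylphenyl brings a number 32 percentage points lower from compound 2 to compound 3 (beyond the scatter) here, and the one added methyl brings a number 40 percentage points lower from compound 1 to compound 3 (beyond the scatter) as well. Adding a group to the ring of compound 1 can therefore matter, although the chloro of compound 2 left the number within the scatter. Nothing at hand explains the drop. The chloro and the added methyl sit in different places, so the effects of group and place remain unseparated. On these data alone, whether a methoxy in the place of that methyl would also lower the response stays open.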